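Two Aryl Swaps on a Shared Quinoline Ether Core

This account rests on a few compounds, and the source may have more. Where it says the series, first, only, none or still open, it means among the compounds named here.

The study measured cytotoxicity in a functional assay on NCI-H460 cells (Homo sapiens) for cytotoxicity, read by MTT assay, with a stated time of 72 h; a lower number here means a stronger inhibitor, a higher number a weaker inhibitor. Compound 1, with the structure `COc1cc2c(Oc3ccc(NC(=O)c4nn(-c5ccccc5Br)c(=O)c5ccccc45)cc3F)ccnc2cc1OCCCN1CCCC1`, gives 320 nM in this assay. Compound 2, with the structure `COc1cc2c(Oc3ccc(NC(=O)c4nn(-c5ccc([N+](=O)[O-])cc5)c(=O)c5ccccc45)cc3F)ccnc2cc1OCCCN1CCCC1`, differs from compound 1 only in one place: 4-nitrophenyl in place of 2-bromophenyl on an aromatic nitrogen. That change made a step of a 3.9-fold higher number from compound 1 to compound 2 (0.59 log units; beyond the scatter), so compound 2 gives 1240 nM in this assay.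

Compound 3, with the structure `COc1cc2c(Oc3ccc(NC(=O)c4nn(-c5ccccc5Br)c(=O)c5ccccc45)cc3F)ccnc2cc1OCCCN1CCN(C)CC1`, carries a different basic side chain; the difference between its core and that of compound 1 is 4-methylpiperazin-1-yl in place of pyrrolidin-1-yl on a saturated chain carbon, three bonds along the chain from an oxygen on an aromatic ring. This change produced a step of a 1.1-fold lower number from compound 1 to compound 3 (0.04 log units; within the scatter), and compound 3 gives 290 nM in this assay.

Compound 4, with the structure `COc1cc2c(Oc3ccc(NC(=O)c4nn(-c5ccc([N+](=O)[O-])cc5)c(=O)c5ccccc45)cc3F)ccnc2cc1OCCCN1CCN(C)CC1`, has not yet been measured. It differs from compound 3 in exactly the way that compound 2 differs from compound 1: 4-nitrophenyl in place of 2-bromophenyl on an aromatic nitrogen. The surroundings of the change are described in the same words in both pairs, so it is the same change carried onto the core of compound 3.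

The expectation for compound 4 rests on the step of a 3.9-fold higher number from compound 1 to compound 2 (0.59 log units; beyond the scatter), since the side chain swap of a 1.1-fold lower number from compound 1 to compound 3 (0.04 log units; within the scatter) left the number nearly unchanged. The step expected in this assay is a 3.8-fold higher number from compound 3 to compound 4 (0.58 log units; beyond the scatter). Compound 4 is therefore estimated at 1100 nM, with a likely range from 500 nM to 2500 nM.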

Compound 4, half-maximal inhibitory concentration: 980 nM
Estimate against measurement, compound 4: 1.1-fold (0.05 log units) above; measured number inside the range.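

In this assay, putting 4-nitrophenyl in place of 2-bromophenyl on the core of compound 3 gave a 3.4-fold higher number from compound 3 to compound 4 (0.53 log units; beyond the scatter), so the swap carried over to the core bearing the 4-methylpiperazin-1-yl chain at much the size it had on the core bearing pyrrolidin-1-yl: the same change on two cores in this assay, a 3.9-fold higher number (0.59 log units; beyond the scatter) from compound 1 to compound 2 and a 3.4-fold higher number (0.53 log units; beyond the scatter) from compound 3 to compound 4, 1.1-fold (0.06 log units) apart, within the scatter of two such steps. The side chain swap, read on the 4-nitrophenyl pair, gave a 1.3-fold lower number from compound 2 to compound 4 (0.10 log units; within the scatter), and it stayed as small there as it was on the 2-bromophenyl pair: the same change on two cores in this assay, a 1.1-fold lower number (0.04 log units; within the scatter) from compound 1 to compound 3 and a 1.3-fold lower number (0.10 log units; within the scatter) from compound 2 to compound 4, 1.1-fold (0.06 log units) apart, within the scatter of two such steps. Across these four compounds, then, neither change depended on the other, but that rests on two cores in a single cell assay and does not show that the aryl swap would carry to a core with any other side chain, nor does it explain why the step occurs.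

Bromine and nitro also sit at different places on the ring in this pair, so the compounds shown leave open whether the step follows the group or its place. Also open, from the compounds shown here alone, is how a plain phenyl on the aromatic nitrogen, or a morpholine at the end of the side chain, would read in this assay.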